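Chain extension on an aryl ether: outlook for compound 4

This account rests on a few compounds, and the source may have more. Where it says the series, first, only, none or still open, it means among the compounds named here.

Measured so far in a functional assay on MCF7 cells (Homo sapiens) for cytotoxicity; on this read-out higher numbers stand for an effect only at larger amounts of compound and lower numbers for an effect already at smaller amounts:
compound 1 `COc1cc(/C=C\c2ccc(C(C)(C)C)cc2)cc(OC)c1OC` gives 1.57 uM
compound 2 `COc1cc(/C=C\c2ccc(C(C)C)cc2)cc(OC)c1OC` gives 1.4 uM
compound 3 `CCOc1ccc(/C=C\c2cc(OC)c(OC)c(OC)c2)cc1` gives 9.6 uM

Compounds 1 and 2 share one core and differ only by methyl in place of hydrogen on a saturated chain carbon bound to an aromatic carbon and two saturated chain carbons; the step is a 1.1-fold higher number from compound 2 to compound 1 (0.05 log units; within the scatter). Compound 3 differs from compound 2 by ethoxy in place of isopropyl on an aromatic carbon, with a 6.9-fold higher number from compound 2 to compound 3 (0.84 log units; beyond the scatter), and against compound 1 the step is a 6.1-fold higher number from compound 1 to compound 3 (0.79 log units; beyond the scatter), so compound 3 stands at the highest number of the three in this assay.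

Compound 4 `CCCOc1ccc(/C=C\c2cc(OC)c(OC)c(OC)c2)cc1` is not yet measured. It differs from compound 3 by methyl in place of hydrogen on a saturated chain carbon, two bonds along the chain from an oxygen on an aromatic ring. This is the same kind of change as from compound 2 to compound 1, but not the same: there the methyl enters on a saturated chain carbon bound to an aromatic carbon and two saturated chain carbons, here on a saturated chain carbon two bonds along the chain from an oxygen on an aromatic ring.

For compound 4 a step of about a 1.2-fold lower number from compound 3 to compound 4 (0.08 log units; within the scatter) in this assay is expected, resting on the small step of a 1.1-fold higher number from compound 2 to compound 1 (0.05 log units; within the scatter) that the same kind of change made. Compound 4 is therefore estimated at 8 uM, between 3 uM and 20 uM.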

Compound 4, concentration for half-maximal effect: 6.6 uM
The estimate for compound 4 lay 1.2-fold (0.08 log units) above the measured number, and the stated range covers the measured number.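

In this assay, the methyl change reads the same on both cores: the same change on two cores in this assay, a 1.1-fold higher number (0.05 log units; within the scatter) from compound 2 to compound 1 and a 1.5-fold lower number (0.16 log units; within the scatter) from compound 3 to compound 4, 1.6-fold (0.21 log units) apart, within the scatter of two such steps.

On the ether core, the step is a 1.5-fold lower number from compound 3 to compound 4 (0.16 log units; within the scatter), so going from ethoxy to propoxy gives no change that can be told from scatter, but two pairs with the methyl at different places show only agreement in these cases and no rule for carrying the change to other cores. The difference between the ether and alkyl groups remains, with propoxy in place of isopropyl giving a 4.7-fold higher number from compound 2 to compound 4 (0.67 log units; beyond the scatter) and propoxy in place of tert-butyl giving a 4.2-fold higher number from compound 1 to compound 4 (0.62 log units; beyond the scatter), so the added methyl does not remove that gap.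

Going by these compounds, it remains open whether a longer chain such as butoxy would also stay within the scatter of propoxy or would start to shift the number. Also open, on these data alone, is how an amine or a carboxylic acid carried on the ether chain would read in this assay.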